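The source may hold more compounds than are shown below. What is called first, only, known or untested is meant among the compounds shown, and "the series" means these compounds.

In an ADME assay on MT4 cells (Homo sapiens) for cytotoxicity (on this read-out lower numbers stand for higher toxicity in this test and higher numbers for lower toxicity in this test), compound 1 (`COc1cccc(NC(=S)Nc2cccc(C(F)(F)F)c2)c1`) gives 26000 nM and compound 2 (`Cc1ccc(NC(=S)Nc2cccc(C(F)(F)F)c2)cc1Cl`) gives 20000 nM. Among the measured compounds shown here, these two values lie within the usual scatter of each other, so compound 1 stands level with compound 2 on the numbers available so far. Compound 3 (`FC(F)(F)c1cccc(NC(=S)Nc2cccc(Br)c2)c1`) has not yet been measured. It differs from compound 1 in one place: bromo in place of methoxy on an aromatic carbon. For the measured compounds named here, no step between measured compounds shows what such a change does in this assay, so the only guide is how close the two known values lie. The expected change, a 1.5-fold lower number from compound 1 to compound 3 (0.18 log units; within the scatter), is a slight move towards a lower number and is not expected to exceed the scatter. For compound 3 the estimate is 17000 nM, with an expected range of 7000 nM to 40000 nM.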

Compound 3, half-maximal cytotoxic concentration: 9200 nM
Compound 3: middle estimate off by 1.8-fold (0.27 log units), on the high side; the range from low to high includes it.
By their numbers in this assay, from the lowest: compound 3; then compounds 2 and 1 (each within the scatter of the next).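

In this assay bromo in place of methoxy on an aromatic carbon, meta to a large group, brings a 2.8-fold lower number from compound 1 to compound 3 (0.45 log units; beyond the scatter) and so moves the read-out towards higher toxicity in this test. Among the compounds shown here, this is the first single-place step available, and it shows that the group at this position can shift the value beyond the scatter, which compounds 1 and 2 alone could not show. No measurement presented accounts for the step.

For the compounds shown here, the single step cannot separate the loss of methoxy from the gain of bromo. It also leaves open whether an amine, a nitrile or a carboxylic acid at this position would give a value nearer to that of compound 1 or compound 3.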